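Swapping a nitrile for a urea on a pyrimidine amine

The compounds below may be only part of what the source reports. "The series", "measured", "known", "first", "only" and "open" are said of these compounds alone.

Compound 1 `Nc1nccc(-c2ccccn2)n1` and compound 2 `N#CNc1nccc(-c2ccncc2)n1` were both tested in a functional assay on the whole organism for inhibition, with Rattus norvegicus as the target, with stated times of 1 h and 3.5 h, at a dose of 100 mg/kg by the oral route; a higher number here means more inhibition at the dose given (going by the name of the read-out), a lower number less inhibition. In this assay compound 1 gives 17%. For compound 2 this assay reports only a limit, < 5%, so no exact number is known for it. Compound 3 `NC(=O)Nc1nccc(-c2ccncc2)n1` has not been measured; it differs from compound 2 in one place: carbamoyl in place of cyano on a nitrogen on an aromatic ring. Since compound 2 sits at the limit (the limit of < 5% in this assay, at which 1 of the 2 values shown sits), little room remains for a fall, and no step beyond the scatter is expected from compound 2 to compound 3, a number at least 3 percentage points higher from compound 2 to compound 3 (that floor lies within the scatter). Compound 3 is therefore estimated at 8%, between 0% and 20%.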

Compound 3, a percentage reported as inhibition, in the whole organism at one dose (the size of the read-out at that dose, not a potency): 12%
Compound 3: the middle estimate sits 4 percentage points below what was measured, within the range that was stated.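

In this assay, carbamoyl in place of cyano on a nitrogen on an aromatic ring gives a number at least 7 percentage points higher from compound 2 to compound 3 (that floor lies within the scatter). Within the data shown here, this is the first reading of a single change at this nitrogen, and it shows no loss on going from cyanoamino to ureido, though no gain can be claimed either. The step is only a floor because compound 2 stands at a limit: the limit of < 5% in this assay, at which 1 of the 3 values shown sits.

Going by these compounds, how an acetyl group or a longer chain on this nitrogen would read remains open. On these data alone, whether any group here can lift the read-out clearly beyond the scatter also remains open.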